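The source may hold more compounds than are shown below. What is called first, only, known or untested is meant among the compounds shown, and "the series" means these compounds.

Of the compounds shown here, three sharing one core have been tested in a functional assay on HeLa cells (Homo sapiens) for cytotoxicity, read by MTT assay, with a stated time of 48 h; a lower number here means a stronger inhibitor, a higher number a weaker inhibitor. Compound 1, `Cc1ccc(Cn2cc(COc3ccc4c(=O)ccoc4c3)nn2)cc1`, gives only the limit of the assay, > 100000 nM, rather than a number. Compound 2, `O=c1ccoc2cc(OCc3cn(Cc4cccc(Br)c4)nn3)ccc12`, likewise gives only the assay limit of > 100000 nM. Compound 3, `Cc1ccccc1Cn1cc(COc2ccc3c(=O)ccoc3c2)nn1`, gives 15300 nM. Two of the three values sit at the limit of > 100000 nM in this assay, at which 2 of the 3 values shown sit, so compound 2 stands at the same limit as compound 1 and apart from compound 3. Among the compounds with values here, the step of an at least 6.5-fold lower number from compound 2 to compound 3 (0.81 log units; beyond the scatter) is the only readable one involving compound 2, while the step that the two limits leave unreadable from compound 1 to compound 2 cannot be sized. Compound 4, `O=c1ccoc2cc(OCc3cn(Cc4cccc([N+](=O)[O-])c4)nn3)ccc12`, differs from compound 2 by nitro in place of bromo on an aromatic carbon. Within the data shown here, no measured step exchanges one group for another on the same aromatic ring, so none bears directly on this change, and the two limits show only that compound 1 and compound 2 are weak inhibitors. Compound 4 is therefore expected to remain near the limit, a step of about a number no higher from compound 2 to compound 4 (the limit leaves the size open), with an estimate of 100000 nM and a range from 30000 nM to 300000 nM.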

Compound 4, half-maximal inhibitory concentration: 17300 nM
Beside the measured number, compound 4's estimate is 5.8-fold (0.76 log units) above it; the measured number lies below the stated range.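

On the six-membered aromatic ring of carbon only, nitro in place of bromo gives an at least 5.7-fold lower number from compound 2 to compound 4 (0.76 log units; beyond the scatter) in this assay, so a change at this one ring carbon can bring a compound from the limit of the assay to a measurable number. Set against the 4-methylphenyl compound, the 3-nitrophenyl group gives an at least 5.7-fold lower number from compound 1 to compound 4 (0.76 log units; beyond the scatter), whereas against the 2-methylphenyl compound it gives a 1.1-fold higher number from compound 3 to compound 4 (0.05 log units; within the scatter), so those two groups cannot be told apart here. The full size of the first two steps stays open because compound 1 and compound 2 give no number: the limit of > 100000 nM in this assay, at which 2 of the 4 values shown sit.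

The compounds shown do not tell whether an amine or a carboxylic acid in place of nitro would read like nitro or like bromo. They also leave open whether nitro would give a similar number on another carbon of this ring.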